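The compounds below may be only part of what the source reports. "The series", "measured", "known", "first", "only" and "open" are said of these compounds alone.

Measured so far:

- compound 1, `COc1ccc(N2C(=O)C(OC(C)=O)C2c2cc(OC)c(OC)c(OC)c2)cc1`, which gives > 1000 nM; this is a limit of the assay, not a number.
- compound 2, `COc1ccc(N2C(=O)C(O)C2c2cc(OC)c(OC)c(OC)c2)cc1`, which gives > 1000 nM; this too is a limit, not a number.
- compound 3, `COc1ccc(C2C(OC(C)=O)C(=O)N2c2cc(OC)c(OC)c(OC)c2)cn1`, which gives > 1000 nM; again a limit, not a number.

All three values come from a functional assay on IMR-32 cells (Homo sapiens) for cytotoxicity; on this read-out lower numbers stand for stronger inhibition and higher numbers for weaker inhibition. Going by the values given here, the one step that can be read between measured compounds is a step that the two limits leave unreadable from compound 1 to compound 2; the change behind it is hydrogen in place of acetyl on an oxygen on a saturated carbon. Because both ends sit at the limit of > 1000 nM in this assay, at which 3 of the 3 values shown sit, nothing can be said about the size of that step in either direction.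

Compound 3 carries the same acetyl on the same kind of oxygen, but its core is a different one from that of compound 1; the difference between the two cores is not broken down here. Compound 4, `COc1ccc(C2C(O)C(=O)N2c2cc(OC)c(OC)c(OC)c2)cn1`, has not yet been measured in this assay. Among the compounds with values here, it differs from compound 3 by hydrogen in place of acetyl on an oxygen on a saturated carbon, and the two places read the same word for word, so this is the same change as the one between compound 1 and compound 2.

The expectation for compound 4 in this assay is therefore a step that the limit leaves unreadable from compound 3 to compound 4, resting on compound 3 giving > 1000 nM and on the change from compound 1 to compound 2 having left both ends at the limit of > 1000 nM in this assay, at which 3 of the 3 values shown sit. Compound 4 is thus estimated at 3000 nM, with a range from 1000 nM to 10000 nM, and the assay is expected most likely to report only a limit again.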

Compound 4, half-maximal inhibitory concentration: > 1000 nM
Compound 4 was reported as a limit; the forecaster's own chance of this, stated with the estimate: 85%; the middle value lies beyond the limit too.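

In this assay compound 4 gives > 1000 nM, which is a limit and not a number. No new step can be read between compound 3 and compound 4, because both ends are limits: the limit of > 1000 nM in this assay, at which 4 of the 4 values shown sit.

The compounds shown leave open how far each of the four lies past that limit, and whether acetoxy to hydroxy shifts the value at all on either core.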